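Series notes: cytotoxicity, step from compound 3 to compound 4

A few compounds are considered here, and "the series" means these few. Any claim that something is new, unique, unknown or untested is made for them only; others in the source may bear on it.

Compound 1 `O=C(N/N=C/c1ccccc1)c1cccnc1` is the parent of the set. Compound 2 `O=C(N/N=C/c1ccc(Br)cc1)c1cccnc1` carries bromo in place of hydrogen on an aromatic carbon, compound 3 `O=C(N/N=C/c1ccc(F)cc1)c1cccnc1` carries fluoro in place of hydrogen on an aromatic carbon, and compound 4 `O=C(N/N=C/c1ccc([N+](=O)[O-])cc1)c1cccnc1` has not yet been measured. In an ADME assay on Vero cells (Chlorocebus sabaeus) for cytotoxicity, read by microscopy (a higher number here means that more compound is tolerated, a lower number that less compound is tolerated), compound 1 gives > 100 ug/mL, which is a limit of the assay and not a number. In this assay compound 2 likewise reaches only the limit > 100 ug/mL. In this assay compound 3 stands at the limit > 100 ug/mL. The measured steps are therefore a step that the two limits leave unreadable from compound 1 to compound 2, a step that the two limits leave unreadable from compound 1 to compound 3 and a step that the two limits leave unreadable from compound 2 to compound 3, none of them readable in size, because of the limit of > 100 ug/mL in this assay, at which 3 of the 3 values shown sit.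

Change to compound 4: nitro in place of fluoro on an aromatic carbon. The three measured steps bear on it only in that each swap at this carbon left the read-out at the limit; as none has a readable size, no direction can be drawn from them. The expectation is that compound 4 also remains at the limit, so that a number no higher from compound 3 to compound 4 (the limit leaves the size open) is expected to be no step beyond the scatter. For compound 4 in this assay the estimate is 100 ug/mL, within 50 ug/mL to 100 ug/mL.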

Compound 4, minimum cytotoxic concentration: >= 0.8 ug/mL
Compound 4: only a limit was reported; the forecaster's own chance of this, stated with the estimate: 80%; the middle value lies beyond the limit too.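

In this assay compound 4 gives >= 0.8 ug/mL, which is a limit of the assay and not a number. Its steps to compound 1, compound 2 and compound 3, which also stand at limits, cannot be read in size. The compounds shown leave open whether hydrogen, bromo, fluoro and nitro at this carbon differ at all in this assay.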